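The source may hold more compounds than are shown below. What is called first, only, known or untested is meant among the compounds shown, and "the series" means these compounds.

Compound 1 `CC[C@H](C)[C@H](NC(=O)c1cccc(Cn2ccnc2)c1)C(=O)Nc1nccs1` gives 42000 nM in an assay on HEK293 cells for displacement of a labelled ligand from Type-2 angiotensin II receptor (Homo sapiens); on this read-out lower numbers stand for stronger inhibition and higher numbers for weaker inhibition. Compound 2 `CC[C@H](C)[C@H](NC(=O)c1cccc(Cn2ccnc2)c1)c1nn[nH]n1` has "not determined" (no result reported) in this assay. Compound 3 `CCCCS(=O)(=O)NNC(=O)[C@@H](NC(=O)c1cccc(Cn2ccnc2)c1)[C@@H](C)CC` carries (butylsulfonyl)amino in place of 1,3-thiazol-2-yl on an amide-type nitrogen, and an at least 2.3-fold higher number from compound 1 to compound 3 (0.37 log units; beyond the scatter). In this assay compound 3 reaches only a limit of the assay, > 100000 nM. Among the three values shown, one sits at the limit of > 100000 nM in this assay, at which 1 of the 3 values shown sits. Compound 4 `CC[C@H](C)[C@H](NC(=O)c1cccc(Cn2ccnc2)c1)C(=O)NNS(=O)(=O)c1ccccc1` differs from compound 3 by phenyl in place of butyl on a sulfonyl sulfur. Among the measured compounds shown here, no measured step touches the group on the sulfonyl sulfur; the one measured step, an at least 2.3-fold higher number from compound 1 to compound 3 (0.37 log units; beyond the scatter), concerns another place and gives no direction here. Compound 4 is therefore expected to stay close to compound 3, with an expected step that the limit leaves unreadable from compound 3 to compound 4. For compound 4 the estimate in this assay is 150000 nM, within 40000 nM to 500000 nM.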

Compound 4, inhibition constant: > 100000 nM
Compound 4 was reported as a limit; the forecaster's own chance of this, stated with the estimate: 70%; the middle value does not contradict the limit.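

With phenyl in place of butyl on the sulfonyl sulfur, the read-out in this assay remains a limit and not a number, so the step between compound 3 and compound 4 cannot be read: the limit of > 100000 nM in this assay, at which 2 of the 4 values shown sit. Phenylsulfonylamino in place of 1,3-thiazol-2-yl gives an at least 2.3-fold higher number from compound 1 to compound 4 (0.37 log units; beyond the scatter), so this loss no longer rests on the butyl chain alone.

On these data alone, how far past the limit either compound lies remains open, as does which of the two gives the higher number. As far as these compounds go, whether methyl or an amine on the sulfonyl sulfur would bring back a readable value also remains open.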